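Phenoxy to propoxy on a flavanone: an expectation

The source may hold more compounds than are shown below. What is called first, only, known or untested is meant among the compounds shown, and "the series" means these compounds.

Measured compounds:
compound 1 `COc1cc2c(cc1CC=C(C)C)C(=O)C[C@@H](c1ccc(Oc3ccccc3)cc1)O2` gives 76%
compound 2 `COc1ccc([C@@H]2C/C(=N/OCc3cn(-c4cc(OC)c(OC)c(OC)c4)nn3)c3cc(CC=C(C)C)c(OC)cc3O2)cc1` gives 29%

In a functional assay on HCT-116 cells (Homo sapiens) for inhibition, read by sulforhodamine B assay, with a stated time of 48 h, tested at 50 uM (on this read-out lower numbers stand for less inhibition of growth and higher numbers for more inhibition of growth at the one concentration tested), compound 1 stands highest of the two numbers shown. For the measured compounds named here, the only other measured compound, compound 2, sits well below it in this assay, a gap beyond the usual scatter.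

Compound 3 `CCCOc1ccc([C@@H]2CC(=O)c3cc(CC=C(C)C)c(OC)cc3O2)cc1` differs from compound 1 in one place: propyl in place of phenyl on an oxygen on an aromatic ring. Going by the values given here, no measured pair shows this change, so only a guess can be made. A modest step downward is expected, a number 18 percentage points lower from compound 1 to compound 3 (beyond the scatter), though a step within the scatter cannot be ruled out. Compound 3 is therefore estimated at 58%, with a range from 35% to 80%.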

Compound 3, percent growth inhibition at one concentration: 63%
For compound 3 the middle estimate is 5 percentage points below the measured one; measured number inside the range.
By their numbers in this assay, from the lowest: compound 2; then compound 3; then compound 1.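

In this assay, the change from phenoxy to propoxy on the shared core gives a number 13 percentage points lower from compound 1 to compound 3 (beyond the scatter). For the compounds shown here, this is the first direct reading at this position: the step is modest, and with no aromatic ring on the oxygen, compound 3 still retains much of the inhibition of growth seen with compound 1. Nothing available accounts for the step.

As far as these compounds go, whether a longer chain such as hexyl, or a propyl chain ending in an amine or a carboxylic acid, would give a higher or lower number remains open.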